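The source may report more compounds than this note shows. Statements on the series, on what has been measured and on what is new or still open speak of the compounds shown alone.

- Compound 1 `CCCCCCCCCCCCOc1ccc(C(=O)/C=C/c2c(/C=C/c3ccc(OC)cc3)cc(OC)cc2OC)cc1`: 7.9 ug/mL
- Compound 2 `COc1ccc(/C=C/c2cc(OC)cc(OC)c2/C=C/C(=O)c2ccc(Cl)c(Cl)c2)cc1`: 5.9 ug/mL

Among the measured compounds shown here, only two numbers are available so far, both from a functional assay on A549 cells (Homo sapiens) for antiproliferative activity, read by MTT assay, with a stated time of 48 h; on this read-out lower numbers stand for stronger inhibition and higher numbers for weaker inhibition. There, compound 2 gives 5.9 ug/mL and compound 1 gives 7.9 ug/mL. These two values lie within the usual scatter of each other, so they cannot be ranked, and compound 2 stands level with compound 1.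

The next compound to be tested is compound 3 `COc1ccc(/C=C/c2cc(OC)cc(OC)c2/C=C/C(=O)c2cccc(OC)c2)cc1`. It keeps the rest of compound 2 but has 3-methoxyphenyl in place of 3,4-dichlorophenyl on a carbonyl carbon.

For the measured compounds named here, no measured pair of compounds isolates this change, so any expectation rests on thin evidence. Compound 1 also carries a different group on that carbonyl carbon, and its value of 7.9 ug/mL remains within the scatter of compound 2. In this assay, therefore, no step beyond the scatter is expected, with only a slight lean towards a higher number. The expected step is a 1.2-fold higher number from compound 2 to compound 3 (0.07 log units; within the scatter). For compound 3 the estimated value is 7 ug/mL, with an expected range from 3.5 ug/mL to 14 ug/mL.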

Compound 3, half-maximal inhibitory concentration: 6.1 ug/mL
Estimate against measurement, compound 3: 1.1-fold (0.06 log units) above, and the stated range covers the measured number.
By their numbers in this assay, from the lowest: compounds 2, 3 and 1 (each within the scatter of the next).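

Among the compounds shown here, compound 3 offers the first comparison at the group on the carbonyl carbon in which only that group changes. In this assay, 3-methoxyphenyl in place of 3,4-dichlorophenyl gives a 1.0-fold higher number from compound 2 to compound 3 (0.01 log units; within the scatter) and so leaves the two compounds level. This swap removes both chlorine atoms and adds one hydrogen-bond acceptor while keeping 8 heavy atoms and a six-membered aromatic ring, yet it produces no readable shift on this read-out, and nothing measured here offers an explanation for that.

From the compounds shown here alone, the open question is how much change this position can take: both groups compared here are uncharged substituted phenyl rings, so it remains unknown whether an amine or a carboxylic acid on that ring, or a pyridine ring in its place, would move the number beyond the scatter. It is also unknown whether the same swap would stay this quiet in this assay if the methoxy groups on the shared core were replaced, for example by hydroxyl groups.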